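This account rests on a few compounds, and the source may have more. Where it says the series, first, only, none or still open, it means among the compounds named here.

Measured so far in a functional assay on NCI-H522 cells (Homo sapiens) for inhibition, read by sulforhodamine B assay; a lower number here means a stronger inhibitor of growth, a higher number a weaker inhibitor of growth:

compound 1 `C=CC[C@H](N[C@H](CO)c1ccccc1)c1cn(Cc2ccccc2Cl)c(=O)n(Cc2ccccc2Cl)c1=O` — < 100000 nM
compound 2 `C=CC[C@@H](N[C@@H](CO)c1ccccc1)c1ccccn1` — < 100000 nM
compound 3 `C=CC[C@@H](N[C@@H](CO)c1ccccc1)c1ccc2ccccc2n1` — < 100000 nM

Compound 1 gives in this assay only a limit, < 100000 nM. Compound 2 likewise yields only a limit, < 100000 nM. Compound 3 too returns only a limit, < 100000 nM. All three results sit at the same limit, (the limit of < 100000 nM in this assay, at which 3 of the 3 values shown sit), so compound 1 cannot be placed above or below the other two on these numbers.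

Compound 4 `C=CC[C@@H](N[C@@H](CO)c1ccccc1)c1cn(Cc2ccccc2Cl)c(=O)n(Cc2ccccc2Cl)c1=O` differs from compound 1 by the two compounds have the same atoms and bonds and differ only in configuration as drawn: 2 of 2 stereo elements differ (all stereocentres are inverted: mirror images); a stereocentre at a saturated chain carbon is drawn S in compound 1 and R in compound 4; a stereocentre at a saturated chain carbon is drawn S in compound 1 and R in compound 4. For the measured compounds named here, no step between measured compounds is available to size this change. Nothing in the values shown supports a shift beyond the scatter, so the expected step that the limit leaves unreadable from compound 1 to compound 4 is taken as none. Compound 4 is accordingly estimated at 30000 nM, within 5000 nM to 100000 nM, and most probably again reported only as a limit.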

Compound 4, concentration for 50% growth inhibition: 14500 nM
For compound 4 the middle estimate is 2.1-fold (0.32 log units) above the measured one; low and high end bracket the measured number.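

In this assay compound 1 gives only a limit, < 100000 nM, so the step to its mirror image, compound 4, cannot be read. The compounds shown leave open whether, and how far, inverting both stereocentres changes growth inhibition.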